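A few compounds are considered here, and "the series" means these few. Any claim that something is new, unique, unknown or untested is made for them only; others in the source may bear on it.

Measured compounds:
- compound 1 `COc1cc(/C=C/C(=O)OCCCO[N+](=O)[O-])ccc1OCCCO[N+](=O)[O-]`; in a functional assay on M14 cells (Homo sapiens) for cytotoxicity, read by resazurin assay, with a stated time of 72 h (a lower number here means a stronger inhibitor, a higher number a weaker inhibitor), compound 1 gives > 50000 nM, which is a limit of the assay and not a number.
- compound 2 `O=C(/C=C/c1ccc(OCCCCCCO[N+](=O)[O-])c(O)c1)OCCCCCCO[N+](=O)[O-]`; compound 2 gives > 50000 nM, again a limit.
- compound 3 `COc1cc(/C=C/C(=O)OCCCCCCO[N+](=O)[O-])ccc1OCCCCCCO[N+](=O)[O-]`; compound 3 gives > 50000 nM, also a limit.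

All three values sit at the limit of > 50000 nM in this assay, at which 3 of the 3 values shown sit. Going by the values given here, the one measured single-point change, from compound 3 to compound 2, is hydrogen in place of methyl on an oxygen on an aromatic ring and gives a step that the two limits leave unreadable from compound 3 to compound 2. The cores of compound 1 and compound 3 differ in a way that is not broken down here.

Compound 4 `O=C(/C=C/c1ccc(OCCCO[N+](=O)[O-])c(O)c1)OCCCO[N+](=O)[O-]` is not yet measured. It stands to compound 1 as compound 2 stands to compound 3: hydrogen in place of methyl on an oxygen on an aromatic ring, the same change at the same place. Given that both members of the measured pair sit at the limit, the step is expected to be a number no higher from compound 1 to compound 4 (the limit leaves the size open), resting on a step that the two limits leave unreadable from compound 3 to compound 2 and (the limit of > 50000 nM in this assay, at which 3 of the 3 values shown sit). Compound 4 is therefore estimated at 50000 nM, most probably reported as a limit rather than a number.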

Compound 4, half-maximal inhibitory concentration: 8960 nM
The estimate for compound 4 lay 5.6-fold (0.75 log units) above the measured number; the whole stated range lies above it.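

In this assay, methoxy to hydroxy on the core of compound 1 gives an at least 5.5-fold lower number from compound 1 to compound 4 (0.74 log units; beyond the scatter), so the change counts on this core. From the compounds shown here alone, on the core of compound 3 the same change gives a step that cannot be read, since compound 3 and compound 2 both sit at a limit of the assay: the limit of > 50000 nM in this assay, at which 3 of the 4 values shown sit. Whether the change carries from one core to the other is therefore neither confirmed nor refuted, and the full size of the step on the core of compound 1 also stays open, as the value of compound 1 is a limit.

Still open, going by these compounds, is whether the lower number of compound 4 is specific to the hydroxy. An amine or a carboxylic acid at the same place on the core of compound 4 would test this.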